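A few compounds are considered here, and "the series" means these few. Any claim that something is new, unique, unknown or untested is made for them only; others in the source may bear on it.

Measured compounds:
Compound 1 `Cc1ccc(N2CCN(Cn3nc(-c4ccc5c(c4)OCCO5)oc3=S)CC2)c(C)c1` gives 28400 nM in a functional assay on HepG2 cells (Homo sapiens) for antiproliferative activity, read by MTT assay, with a stated time of 48 h; a higher number here means a weaker inhibitor, a lower number a stronger inhibitor.
Compound 2 `Fc1ccccc1N1CCN(Cn2nc(-c3ccc4c(c3)OCCO4)oc2=S)CC1` gives > 50000 nM in this assay, which is a limit of the assay and not a number.
Compound 3 `S=c1oc(-c2ccc3c(c2)OCCO3)nn1CN1CCN(c2cccc(Cl)c2Cl)CC1` gives > 50000 nM in this assay, again a limit of the assay.

Compound 3 therefore stands at the ceiling of this assay, at the limit of > 50000 nM in this assay, at which 2 of the 3 values shown sit. Against compound 1 its position is given only as an at least 1.7-fold higher number from compound 1 to compound 3 (0.24 log units; that floor lies within the scatter), and against compound 2 only as a step that the two limits leave unreadable from compound 2 to compound 3.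

Compound 4 `S=c1oc(-c2ccc3c(c2)OCCO3)nn1CN1CCN(c2ccc(Cl)cc2)CC1` differs from compound 3 in one place: 4-chlorophenyl in place of 2,3-dichlorophenyl on an amine nitrogen in a ring. Within the data shown here, no measured step exchanges one chlorophenyl for another on that ring nitrogen. The steps that come nearest are an at least 1.7-fold higher number from compound 1 to compound 2 (0.24 log units; that floor lies within the scatter) and an at least 1.7-fold higher number from compound 1 to compound 3 (0.24 log units; that floor lies within the scatter), each of them a floor that lies within the scatter, so that among the three measured compounds every change on this ring nitrogen has left the number high. On that basis no step beyond the scatter is expected in this assay from compound 3 to compound 4, and a further limit reading is quite possible. Compound 4 is expected at 45000 nM, within 15000 nM to 150000 nM. The expected step is an at least 1.1-fold lower number from compound 3 to compound 4 (0.04 log units; that floor lies within the scatter).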

Compound 4, half-maximal inhibitory concentration: > 50000 nM
Compound 4: only a limit was reported (the forecaster's own chance of this, stated with the estimate: 55%); at least 1.1-fold (0.04 log units) between middle value and limit.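

Compound 4 shows that a single chlorine, as 4-chlorophenyl on the amine nitrogen in a ring, leaves the reading in this assay at a limit of the assay, as the 2,3-dichlorophenyl of compound 3 did, so removing one chlorine brought no reading that is a number. Among these compounds, the only readable step is an at least 1.7-fold higher number from compound 1 to compound 4 (0.24 log units; that floor lies within the scatter), while the steps among the three compounds at the limit cannot be read. Compound 1, with its 2,4-dimethylphenyl, thus remains the only one of the four with a reading that is not a limit, and the limit now covers most of the values: the limit of > 50000 nM in this assay, at which 3 of the 4 values shown sit.

The compounds shown leave open whether a plain phenyl or a 4-methoxyphenyl on that ring nitrogen would give a reading that is a number. They also leave open how far any group there could move the reading, since the limits hide the true size of every step among compounds 2, 3 and 4.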